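Aryl amide variation on the shared core: compound 3 to compound 4

The source may hold more compounds than are shown below. What is called first, only, known or untested is meant among the compounds shown, and "the series" means these compounds.

Measured so far in a functional assay on PC-3 cells (Homo sapiens), with a stated time of 24 h, tested at 10 uM; on this read-out lower numbers stand for less inhibition and higher numbers for more inhibition at the one concentration tested (going by the name of the read-out):
- compound 1 `O=C(Nc1cccc(OCCc2ccccn2)c1)C1CCCN(C(=O)c2cc(C(F)(F)F)cc(C(F)(F)F)c2)C1`: < 30%
- compound 2 `O=C(Nc1cccc(S(=O)(=O)N2CCCC2)c1)C1CCCN(C(=O)c2cc(C(F)(F)F)cc(C(F)(F)F)c2)C1`: < 30%
- compound 3 `O=C(Nc1ccc(Cl)cc1)C1CCCN(C(=O)c2cc(C(F)(F)F)cc(C(F)(F)F)c2)C1`: 22%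

Among the compounds with values here, compound 3 gives the only number in this assay, and it stands low. For compound 1 the value < 30% is a limit of the assay. For compound 2 the value < 30% is likewise a limit. The step that the two limits leave unreadable from compound 1 to compound 2 cannot be read, which follows from the limit of < 30% in this assay, at which 2 of the 3 values shown sit.

Compound 4 `Cc1nc(-c2cccc(NC(=O)C3CCCN(C(=O)c4cc(C(F)(F)F)cc(C(F)(F)F)c4)C3)c2)cs1` is not yet measured. It differs from compound 3 by 3-(2-methyl-1,3-thiazol-4-yl)phenyl in place of 4-chlorophenyl on an amide-type nitrogen. Within the data shown here, no measured step bears on this change; the set offers no readable step at all. Inhibition for compound 4 in this assay is therefore expected near 25%, from 5% to 50%. The step of a number 3 percentage points higher from compound 3 to compound 4 (within the scatter) is expected to remain within scatter.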

Compound 4, a percentage reported as inhibition, at one concentration (the size of the read-out at that concentration, not a potency): 42%
The estimate for compound 4 lay 17 percentage points below the measured number; the range from low to high includes it.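

In this assay, within the data shown here, the change on the amide-type nitrogen gives the first readable step: a number 20 percentage points higher from compound 3 to compound 4 (beyond the scatter). The 2-methyl-1,3-thiazol-4-yl group on the aromatic carbon also separates from both earlier groups, with a number at least 12 percentage points higher from compound 2 to compound 4 (beyond the scatter) and a number at least 12 percentage points higher from compound 1 to compound 4 (beyond the scatter). Compound 1 and compound 2 each stand at a limit rather than a number, and the step between them cannot be read: the limit of < 30% in this assay, at which 2 of the 4 values shown sit.

On these data alone, whether an amine or a carboxylic acid in place of the methyl of 2-methyl-1,3-thiazol-4-yl would shift inhibition remains open. Also open, as far as these compounds go, is whether the step from 4-chlorophenyl holds with a chlorine kept on the phenyl ring of compound 4.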